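Notes on three measured acids and a fourth to come

The source may hold more compounds than are shown below. What is called first, only, known or untested is meant among the compounds shown, and "the series" means these compounds.

Measured so far, in an assay on isolated protein for inhibition of Polyunsaturated fatty acid 5-lipoxygenase (Homo sapiens), read by HPLC, with a stated time of 15 min, in the presence of a further agent that is not named here; a lower number here means a stronger inhibitor, a higher number a weaker inhibitor:
compound 1 `CCCCC(Sc1ccc(OCCCOc2cccc(C)c2)cc1)C(=O)O` gives 4800 nM;
compound 2 `CCCCC(Sc1ccc(OCCCOc2cccc(C(F)(F)F)c2)cc1)C(=O)O` gives 1600 nM;
compound 3 `CCCCC(Sc1ccc(OCCCOc2cccc(C(C)C)c2)cc1)C(=O)O` gives 1400 nM.

Compound 3 shows the lowest number of the three, but its gap to compound 2 is within the scatter, so the two are not separable; only compound 1 stands apart, as a 3.4-fold lower number from compound 1 to compound 3 (0.54 log units; beyond the scatter).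

Compound 4 `CCCCC(Sc1ccc(OCCCOc2ccc(C)cc2)cc1)C(=O)O` differs from compound 3 by 4-methylphenyl in place of 3-isopropylphenyl on an oxygen on a saturated carbon. Compound 1 also carries a methyl on an aromatic carbon, and the step of a 3.4-fold lower number from compound 1 to compound 3 (0.54 log units; beyond the scatter) shows what exchanging methyl for isopropyl did. For the measured compounds named here, no measured step covers the other part of the change, so this part is left open. The methyl-for-isopropyl part points to a higher number in this assay, estimated as a 3.2-fold higher number from compound 3 to compound 4 (0.51 log units; beyond the scatter). Compound 4 is expected at 4500 nM, with a range from 1500 nM to 13000 nM.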

Compound 4, half-maximal inhibitory concentration: 5200 nM
Compound 4: the middle estimate sits 1.2-fold (0.06 log units) below what was measured; the measured number falls inside the stated range.
By their numbers in this assay, from the lowest: compounds 3 and 2 (each within the scatter of the next); then compounds 1 and 4 (each within the scatter of the next).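

In this assay, shifting the methyl leaves the number within the scatter, a 1.1-fold higher number from compound 1 to compound 4 (0.03 log units; within the scatter), so 3-methylphenyl and 4-methylphenyl on this oxygen are not separable. The larger steps come with exchanging the group itself, a 3.7-fold higher number from compound 3 to compound 4 (0.57 log units; beyond the scatter) and a 3.3-fold higher number from compound 2 to compound 4 (0.51 log units; beyond the scatter), both beyond the scatter. No evidence on the cause of these steps is available.

Open, from the compounds shown here alone, is how an amine or a methoxy group in place of methyl on this ring would read, and whether the gaps seen for isopropyl and trifluoromethyl hold with either group placed where compound 4 carries its methyl.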